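Moving a chlorine from 4-chlorophenyl to 2-chlorophenyl

The compounds below may be only part of what the source reports. "The series", "measured", "known", "first", "only" and "open" are said of these compounds alone.

In a functional assay on MOLT-4 cells (Homo sapiens) for antiproliferative activity, read by MTT assay, with a stated time of 48 h (on this read-out lower numbers stand for stronger inhibition and higher numbers for weaker inhibition), compound 1 `O=C(CCCCCn1cc(Nc2ncc(Cl)c(Nc3ccc(F)cc3)n2)cn1)NO` gives 120 nM and compound 2 `O=C(CCCCCn1cc(Nc2ncc(Cl)c(Nc3ccc(Cl)cc3)n2)cn1)NO` gives 80 nM. These two values lie within the scatter of each other, so compound 2 stands level with compound 1 and the pair cannot be ranked. Compound 3 `O=C(CCCCCn1cc(Nc2ncc(Cl)c(Nc3ccccc3Cl)n2)cn1)NO` has not yet been measured. It has the same atoms as compound 2, joined differently: 2-chlorophenyl in place of 4-chlorophenyl on a nitrogen on an aromatic ring. Among the compounds with values here, only one measured step comes close to this change, namely a 1.5-fold lower number from compound 1 to compound 2 (0.18 log units; within the scatter), with chloro in place of fluoro on an aromatic carbon. Within the data shown here, that step exchanges one halogen for another, whereas the new change swaps 4-chlorophenyl for 2-chlorophenyl, and no measured pair shows such a swap. The evidence is therefore indirect, and the range has to stay wide. Among the measured compounds shown here, with only that small step to go on, no change beyond the scatter is expected in this assay, and the estimated step is a 1.5-fold higher number from compound 2 to compound 3 (0.18 log units; within the scatter). For compound 3 the expected value is 120 nM, with an estimated range from 40 nM to 360 nM.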

Compound 3, half-maximal inhibitory concentration: 630 nM
The estimate for compound 3 lay 5.3-fold (0.72 log units) below the measured number; the measured number lies above the stated range.
By their numbers in this assay, from the lowest: compounds 2 and 1 (each within the scatter of the next); then compound 3.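

In this assay, moving the chlorine alone, with every atom kept, gives a 7.9-fold higher number from compound 2 to compound 3 (0.90 log units; beyond the scatter), so the place of the chlorine on this phenyl ring, attached through the amino nitrogen, matters far more than the earlier halogen exchange suggested. Compound 3 also stands apart from the 4-fluorophenyl analogue, with a 5.3-fold higher number from compound 1 to compound 3 (0.72 log units; beyond the scatter), which shows that 2-chlorophenyl gives weaker inhibition than either of the two 4-halophenyl groups, while those two groups remain level with each other. The compounds offer no measurement that bears on why this shift in the chlorine weakens the read-out.

The three compounds cannot show whether the loss belongs to chlorine specifically or would also appear with 2-fluorophenyl or 2-methylphenyl, which would separate the effect of that atom from that of having any group at this place on the ring. They also leave open where 3-chlorophenyl would fall, and whether the unsubstituted phenyl group would sit nearer to compound 2 or to compound 3.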